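Adding a Hydroxyl to the Hydroxamate Side Chain

A few compounds are considered here, and "the series" means these few. Any claim that something is new, unique, unknown or untested is made for them only; others in the source may bear on it.

Compound 1, `O=C(NC1(C(=O)NO)CCC1)c1ccc(C#Cc2ccccc2)cc1`, in a physicochemical assay for lipophilicity (a lower number here means a more polar compound, a higher number a more lipophilic compound), gives > 3, a limit of the assay rather than a number. Compound 3, `CC(NC(=O)c1ccc(C#Cc2ccccc2)cc1)C(=O)NO`, in this assay gives > 3, also a limit. Compound 2, `O=C(C[C@H](NC(=O)c1ccc(C#Cc2ccccc2)cc1)C(=O)NO)NCCCO`, in this assay gives 2.

Compound 3 thus sits at the limit described in the limit of > 3 in this assay, at which 2 of the 3 values shown sit, with no number of its own. Compound 4, `O=C(N[C@H](CO)C(=O)NO)c1ccc(C#Cc2ccccc2)cc1`, differs from it by a group of 7 heavy atoms (3 carbon, 1 nitrogen, 3 oxygen; no ring) in place of a group of 6 heavy atoms (3 carbon, 1 nitrogen, 2 oxygen; no ring), on an amide-type nitrogen. Within the data shown here, the only measured step on this side chain, a step that the two limits leave unreadable from compound 1 to compound 3, is unreadable, and compound 2 is tied to compound 3 by no single step, so only its lower value can guide the guess. Compound 4 is expected to fall by a number at least 0.80 log units lower from compound 3 to compound 4 (beyond the scatter). The estimate for compound 4 is 2.2, between 1.6 and 2.8.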

Compound 4, distribution coefficient: 2
Beside the measured number, compound 4's estimate is 0.20 log units above it; the measured number falls inside the stated range.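

Among these compounds, changing the side chain on the amide-type nitrogen gives the first readable steps at this position in this assay: a number at least 1.00 log units lower from compound 3 to compound 4 (beyond the scatter), and a number at least 1.00 log units lower from compound 1 to compound 4 (beyond the scatter). The step from compound 1 to compound 3 cannot be read, whereas compound 4 brings a number to compare against. The true size of both new steps stays open because compound 1 and compound 3 carry only a limit: the limit of > 3 in this assay, at which 2 of the 4 values shown sit.

The compounds shown leave open how an amine or a carboxylic acid in place of the hydroxyl would compare, and how a longer chain ending in a hydroxyl would compare with compound 4.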